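The compounds below may be only part of what the source reports. "The series", "measured", "known", "first", "only" and "open" are said of these compounds alone.

In a functional assay on SW480 cells (Homo sapiens) for antiproliferative activity, read by MTT assay, with a stated time of 48 h (a lower number here means a stronger inhibitor, a higher number a weaker inhibitor), compound 2 (`COC/C1=C/C[C@](C)(CCC=C(C)C)/C=C/[C@@H](OC(=O)C=C(C)C)[C@](C)(O)/C=C/C1=O`) gives 3850 nM and lies within the scatter of both compound 1 (`CC(=O)OC/C1=C/C[C@](C)(CCC=C(C)C)/C=C/[C@@H](OC(=O)C=C(C)C)[C@](C)(OC(C)=O)/C=C/C1=O`) at 3520 nM and compound 3 (`CC(=O)O[C@]1(C)/C=C/C(=O)/C(CO)=C\C[C@](C)(CCC=C(C)C)/C=C/[C@H]1OC(=O)C=C(C)C`) at 2010 nM in this small set. Compound 4 (`CC(C)=CCC[C@]1(C)/C=C/[C@@H](OC(=O)C=C(C)C)[C@](C)(O)/C=C/C(=O)/C(CN(C(C)C)C(C)C)=C\C1`) carries diisopropylamino in place of methoxy on a saturated chain carbon bound to a double-bonded ring carbon. Going by the values given here, the one measured step that bears on this, hydrogen in place of acetyl on an oxygen on a saturated carbon (a 1.8-fold lower number from compound 1 to compound 3 (0.24 log units; within the scatter)), stays small. Among the compounds with values here, no measured compound carries an amine, so the guide is weak and no step beyond the scatter is expected. The estimated change is a 1.3-fold lower number from compound 2 to compound 4 (0.11 log units; within the scatter) and its direction is uncertain. For compound 4 the expected value is 3000 nM with an estimated range of 1000 nM to 8000 nM around it.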

Compound 4, half-maximal inhibitory concentration: 750 nM
Compound 4: middle estimate off by 4.0-fold (0.60 log units), on the high side; the measured number lies below the stated range.
By their numbers in this assay, from the lowest: compound 4; then compounds 3, 1 and 2 (each within the scatter of the next).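

In this assay, diisopropylamino in place of methoxy on a saturated chain carbon bound to a double-bonded ring carbon gives a 5.1-fold lower number from compound 2 to compound 4 (0.71 log units; beyond the scatter) and this step lies beyond the scatter. The earlier step at this place, a 1.8-fold lower number from compound 1 to compound 3 (0.24 log units; within the scatter), stayed within the scatter, so only compound 4 shows that a change here can move the number. Going by these compounds, whether dimethylamino, morpholine or a carboxylic acid in this place would give a step of like size stays open. No measurement shown gives a cause for the step.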